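A few compounds are considered here, and "the series" means these few. Any claim that something is new, unique, unknown or untested is made for them only; others in the source may bear on it.

Measured so far in a functional assay on U-87MG ATCC cells (Homo sapiens) for cytotoxicity, read by MTT assay, with a stated time of 72 h; on this read-out lower numbers stand for stronger inhibition and higher numbers for weaker inhibition:
- compound 1 `CN(C)CCn1cnnc1-c1cc(Oc2ccc(NC(=O)N/N=C/c3cccc(Br)c3)cc2F)ccn1` — compound 1 gives 830 nM
- compound 2 `CN(C)CCn1cnnc1-c1cc(Oc2ccc(NC(=O)N/N=C/c3ccc(Cl)cc3)cc2F)ccn1` — compound 2 gives 1370 nM

Compound 2 has the highest of the two numbers, and its nearest neighbour is compound 1; the step of a 1.7-fold higher number from compound 1 to compound 2 (0.22 log units; within the scatter) is within the scatter, so the two values cannot be ordered.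

Compound 3 `Cc1cc(/C=N/NC(=O)Nc2ccc(Oc3ccnc(-c4nncn4CCN(C)C)c3)c(F)c2)cc(C)c1O` differs from compound 2 in one place: 4-hydroxy-3,5-dimethylphenyl in place of 4-chlorophenyl on a carbon with a double bond to nitrogen. Among the compounds with values here, the only measured step, a 1.7-fold higher number from compound 1 to compound 2 (0.22 log units; within the scatter), exchanges one halogenated ring for another at the same carbon with a double bond to nitrogen and stays within the scatter. Within the data shown here, no measured pair brings a 4-hydroxy-3,5-dimethylphenyl group into this place, so nothing here points in either direction. The expected step of a 1.1-fold lower number from compound 2 to compound 3 (0.06 log units; within the scatter) is therefore one of no change beyond the scatter, with a wide allowance for an untested group. Compound 3 is estimated at 1200 nM, with a range from 400 nM to 3600 nM.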

Compound 3, half-maximal inhibitory concentration: 7710 nM
Estimate against measurement, compound 3: 6.4-fold (0.81 log units) below, and the stated range ends below it.
By their numbers in this assay, from the lowest: compounds 1 and 2 (each within the scatter of the next); then compound 3.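

Replacing the halogenated ring on the carbon with a double bond to nitrogen by 4-hydroxy-3,5-dimethylphenyl gives a 5.6-fold higher number from compound 2 to compound 3 (0.75 log units; beyond the scatter) and a 9.3-fold higher number from compound 1 to compound 3 (0.97 log units; beyond the scatter) in this assay with both steps pointing to weaker inhibition. This position therefore does respond to a change of ring substituents, which the exchange of 3-bromophenyl for 4-chlorophenyl, within the scatter, did not show. No measurement here explains the weaker inhibition of compound 3.

The entering group differs from both halogenated rings in its hydroxyl and its two methyl groups together, so these compounds do not separate the contribution of each. From the compounds shown here alone, a 4-hydroxyphenyl or a 3,5-dimethylphenyl group at the same carbon would bear on that question, and whether any group here gives stronger inhibition than the halogenated rings remains open.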